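A few compounds are considered here, and "the series" means these few. Any claim that something is new, unique, unknown or untested is made for them only; others in the source may bear on it.

Compound 1 `Clc1ccc2c(NCCNCc3ccc(-c4cccnc4)s3)ccnc2c1` and compound 3 `Clc1ccc2c(NCCNCc3ccc(-c4ccncc4)s3)ccnc2c1` share one core and differ in a single place: pyridin-4-yl in place of pyridin-3-yl on an aromatic carbon. In an ADME assay on HepG2 cells (Homo sapiens) for cytotoxicity, read by MTT assay, with a stated time of 48 h (a lower number here means a stronger inhibitor, a higher number a weaker inhibitor), compound 1 gives 16400 nM, while compound 3 gives 6330 nM, a step of a 2.6-fold lower number from compound 1 to compound 3 (0.41 log units; beyond the scatter). Compound 2 `Clc1ccc2c(NCCCNCc3ccc(-c4cccnc4)s3)ccnc2c1` gives 21600 nM in this assay; how its core differs from that of compound 1 is not broken down here. Compound 4 `Clc1ccc2c(NCCCNCc3ccc(-c4ccncc4)s3)ccnc2c1` has not yet been measured in this assay. It differs from compound 2 by pyridin-4-yl in place of pyridin-3-yl on an aromatic carbon, the same change that was made from compound 1 to compound 3. The step is expected to be a 2.6-fold lower number from compound 2 to compound 4 (0.42 log units; beyond the scatter), beside the earlier one, because compound 2 gives 21600 nM and the same change produced a 2.6-fold lower number from compound 1 to compound 3 (0.41 log units; beyond the scatter). Compound 4 is therefore estimated at 8300 nM, expected to fall between 4000 nM and 17000 nM.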

Compound 4, half-maximal inhibitory concentration: 3320 nM
Estimate against measurement, compound 4: 2.5-fold (0.40 log units) above, outside the stated range (below it).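

In this assay, the swap of pyridin-3-yl for pyridin-4-yl gives a 6.5-fold lower number from compound 2 to compound 4 (0.81 log units; beyond the scatter), so the number falls on this core as it did on the core of compound 1. The two steps do not differ by more than the scatter of two such steps allows: the same change on two cores in this assay, a 2.6-fold lower number (0.41 log units; beyond the scatter) from compound 1 to compound 3 and a 6.5-fold lower number (0.81 log units; beyond the scatter) from compound 2 to compound 4, 2.5-fold (0.40 log units) apart, within the scatter of two such steps. Within the data shown here, this shows that the change carried over in direction and, within that scatter, in size between these two cores, but it rests on only two pairs and shows nothing about any other core.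

The compounds shown leave open what a phenyl or pyridin-2-yl group would give in the same place. They also leave open whether the step would persist with a longer chain.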